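Methoxy for nitro on the shared core: expected binding

The source may report more compounds than this note shows. Statements on the series, on what has been measured and on what is new or still open speak of the compounds shown alone.

Among the measured compounds shown here, compound 2 `CCOC(=O)c1c(N)sc(-c2ccc([N+](=O)[O-])cc2)c1-c1cccc(C(F)(F)F)c1` gives 71.4% in an assay on CHO-K1 cells for displacement of a labelled ligand from adenosine receptor A1 (Homo sapiens), tested at 10 uM (on this read-out lower numbers stand for less inhibition and higher numbers for more inhibition at the one concentration tested (going by the name of the read-out)), the lower of the two numbers so far; compound 1 `CCOC(=O)c1c(N)sc(-c2ccccc2)c1-c1cccc(C(F)(F)F)c1` gives 83.6% in this assay. For the measured compounds named here, the one measured step, a number 12.2 percentage points lower from compound 1 to compound 2 (beyond the scatter), is the only comparison that touches this place. Compound 3 `CCOC(=O)c1c(N)sc(-c2ccc(OC)cc2)c1-c1cccc(C(F)(F)F)c1` differs from compound 2 by methoxy in place of nitro on an aromatic carbon. Going by the values given here, no measured step carries a methoxy, so the estimate is loose. Among the compounds with values here, because the single step of a number 12.2 percentage points lower from compound 1 to compound 2 (beyond the scatter) went down when nitro entered, removing that nitro may let the number rise, though the entering group is untested. Compound 3 is expected to give about 79% (range 62% to 92%), an estimated step of a number 7.6 percentage points higher from compound 2 to compound 3 (within the scatter), upward and near the edge of the scatter.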

Compound 3, a percentage reported as inhibition, at one concentration (the size of the read-out at that concentration, not a potency): 81.5%
Compound 3: the middle estimate sits 2.5 percentage points below what was measured, within the range that was stated.
By their numbers in this assay, from the lowest: compound 2; then compounds 3 and 1 (each within the scatter of the next).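

On this aromatic carbon, para to a large group, the lower number belongs to nitro rather than to substitution as such: a number 10.1 percentage points higher from compound 2 to compound 3 (beyond the scatter), while a number 2.1 percentage points lower from compound 1 to compound 3 (within the scatter) in this assay. Among the three compounds, hydrogen and methoxy cannot be told apart, and only compound 2 stands apart from both. Nothing measured here accounts for this difference between the groups.

As far as these compounds go, whether an amine, a carboxylic acid or a longer chain such as ethoxy at this carbon would stay with hydrogen and methoxy or fall with nitro remains open.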